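The compounds below may be only part of what the source reports. "The series", "measured", "known", "first", "only" and "open" are said of these compounds alone.

Among the compounds with values here, compound 2 `CC(C)(C)OC(=O)N1CCC(O[C@H]2CC[C@H](Oc3cnc(C#N)cn3)CC2)CC1` gives 100% in a functional assay on isolated protein for agonist activity at Glucose-dependent insulinotropic receptor (Rattus norvegicus), read by HTRF and cAMP accumulation (a higher number here means a larger maximal response, a lower number a smaller maximal response), the lower of the two values measured so far, and compound 1 `CC(C)(C)OC(=O)N1CCC(O[C@H]2CC[C@H](Oc3ccc(S(C)(=O)=O)cc3)CC2)CC1` gives 120%. Compound 3 `CC(C)(C)OC(=O)N1CCC(O[C@H]2CC[C@H](Oc3ccc(S(C)(=O)=O)nn3)CC2)CC1` differs from compound 2 in one place: 6-(methylsulfonyl)pyridazin-3-yl in place of 5-cyanopyrazin-2-yl on an oxygen on a saturated carbon. Within the data shown here, the one measured step that bears on a change at this oxygen, a number 20 percentage points lower from compound 1 to compound 2 (beyond the scatter), was modest. Because a number 20 percentage points lower from compound 1 to compound 2 (beyond the scatter) moved the response only modestly, compound 3 is expected to give 105%, between 85% and 125%. This expected step, a number 5 percentage points higher from compound 2 to compound 3 (within the scatter), would stay within the scatter.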

Compound 3, largest response reached (Emax), in percent of the reference or control that the assay uses: 86%
Estimate against measurement, compound 3: 19 percentage points above; the measured number falls inside the stated range.
By their numbers in this assay, from the lowest: compound 3; then compound 2; then compound 1.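

Keeping the methylsulfonyl group does not keep the response: in this assay, exchanging 4-(methylsulfonyl)phenyl for 6-(methylsulfonyl)pyridazin-3-yl gives a number 34 percentage points lower from compound 1 to compound 3 (beyond the scatter). Exchanging 5-cyanopyrazin-2-yl for that same group, with both rings having 2 hetero atoms, gives a number 14 percentage points lower from compound 2 to compound 3 (beyond the scatter). Among these three compounds, the response at this oxygen therefore depends on the ring as well as on the group it carries.

Nothing available explains these differences. From the compounds shown here alone, it remains open how this response would change with an amine or a carboxylic acid on the ring in place of the methylsulfonyl group.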